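The source may report more compounds than this note shows. Statements on the series, on what has been measured and on what is new or still open speak of the compounds shown alone.

Measured in a functional assay on MGC-803 cells (Homo sapiens) for inhibition, read by MTT assay, with a stated time of 48 h; on this read-out lower numbers stand for stronger inhibition and higher numbers for weaker inhibition:
- compound 1 `C/C=C/C(=O)N(Cc1ccc(OC)c([N+](=O)[O-])c1)c1cc(OC)c(OC)c(OC)c1`: 590 nM
- compound 2 `COc1cc(NCc2ccccc2)cc(OC)c1OC`: > 80000 nM (a limit, not a number)
- compound 3 `COCC(=O)N(Cc1ccc(OC)c(O)c1)c1cc(OC)c(OC)c(OC)c1`: 79 nM

Compound 3 stands lowest among the numbers in hand, and so is the strongest of the set. The nearest number belongs to compound 1, and the gap between them lies beyond the usual scatter. Compound 2 offers only a limit and gives no exact point of comparison.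

The next compound to be tested is compound 4 `COc1ccc(CN(C(=O)C(C)Br)c2cc(OC)c(OC)c(OC)c2)cc1O`, which carries 1-bromoethyl in place of methoxymethyl on a carbonyl carbon.

Within the data shown here, no measured pair covers this exchange, so the expectation stays anchored on compound 3 at 79 nM. A small move toward a lower number in this assay is expected, probably not beyond the scatter. The expected step is a 1.6-fold lower number from compound 3 to compound 4 (0.20 log units; within the scatter). For compound 4 the estimated value is 50 nM, with an expected range of 12 nM to 220 nM.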

Compound 4, half-maximal inhibitory concentration: 120 nM
The estimate for compound 4 lay 2.4-fold (0.38 log units) below the measured number, and the stated range covers the measured number.
By their numbers in this assay, from the lowest: compounds 3 and 4 (each within the scatter of the next); then compound 1. At a limit, above all of these: compound 2.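

In this assay the exchange of methoxymethyl for 1-bromoethyl on a carbonyl carbon gives a 1.5-fold higher number from compound 3 to compound 4 (0.18 log units; within the scatter) and so does not separate the two groups. Among these compounds, this is the first single-place comparison, and it shows that the group on this carbonyl carbon can lose its oxygen and take a bromine without a change that can be read in this pair. No measured property of either group bears on this step.

From the compounds shown here alone, it remains open whether the number would hold with a plain ethyl group, which would show whether the bromine matters on its own. Also open, going by these compounds, is how a longer chain, an amine or a carboxylic acid at the same carbonyl carbon would read.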